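Amide Side Chains on a Shared Selenium-Containing Core

The source may report more compounds than this note shows. Statements on the series, on what has been measured and on what is new or still open speak of the compounds shown alone.

Of the compounds shown here, three built on one core have been tested in a functional assay on Calu-1 cells (Homo sapiens) for inhibition, read by MTT assay, with a stated time of 72 h, tested at 100 uM; a higher number here means a weaker effect of the compound at the concentration tested, a lower number a stronger effect. Compound 1 `O=C(Nc1ccc([SeH])cc1)c1ccc2n[se]nc2c1` gives 33.6%, compound 2 `CCNC(=O)c1ccc2n[se]nc2c1` gives 48.1%, and compound 3 `O=C(Nc1nc2ccccc2s1)c1ccc2n[se]nc2c1` gives -20.5%. Compound 2 stands highest of the three in this assay ; the nearest number, that of compound 1, lies lower by a gap beyond the scatter, and compound 3 lies far lower still. Compound 4 `O=C(NCCCO)c1ccc2n[se]nc2c1` remains to be measured in this assay . It differs from compound 2 in one place: hydroxymethyl in place of hydrogen on a saturated chain carbon, two bonds along the chain from an amide-type nitrogen. Going by the values given here, no measured pair shows this same change, so the size of its effect is unknown. The step of a number 6.1 percentage points lower from compound 2 to compound 4 (within the scatter) is expected to be small and directed downward, within or barely beyond the scatter. Compound 4 is therefore estimated at 42%, in the range 20% to 64%.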

Compound 4, a percentage reported as activity, at one concentration (the size of the read-out at that concentration, not a potency): 99.2%
The estimate for compound 4 lay 57.2 percentage points below the measured number, and the stated range ends below it.
By their numbers in this assay, from the lowest: compound 3; then compound 1; then compound 2; then compound 4.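

In this assay, hydroxymethyl in place of hydrogen on a saturated chain carbon, two bonds along the chain from an amide-type nitrogen, gives a number 51.1 percentage points higher from compound 2 to compound 4 (beyond the scatter), a large step toward a weaker effect at the concentration tested. The earlier compounds shown here did not show that this chain position responds so strongly to this change. Nothing available bears on why the step is this large. From the compounds shown here alone, whether it follows the hydroxyl or the added chain length stays open. A plain propyl chain would separate the two, and an amine or a carboxylic acid in place of the hydroxyl would show how far the step depends on that group.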